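Fluorobenzyl changes on the shared core: working notes

The compounds below may be only part of what the source reports. "The series", "measured", "known", "first", "only" and "open" are said of these compounds alone.

Values in a functional assay on A-375 cells (Homo sapiens) for antiproliferative activity; a higher number here means a weaker inhibitor, a lower number a stronger inhibitor:
- compound 1 `O=C(Nc1ccc(-c2cscn2)cc1)C1CCCN(C(=O)c2ccc(F)c(F)c2)C1`: > 20000 nM, a limit of the assay
- compound 2 `O=C(Nc1ccc(-c2cscn2)cc1)C1CCCN(Cc2ccccc2F)C1`: 4000 nM
- compound 3 `O=C(Nc1ccc(-c2cscn2)cc1)C1CCCN(Cc2ccc(F)cc2)C1`: 2250 nM

Compound 3 shares the numeric range with compound 2, within the scatter of it. Next is compound 4 `O=C(Nc1ccc(-c2cscn2)cc1)C1CCCN(Cc2cc(F)cc(F)c2)C1`, with 3,5-difluorophenyl in place of 4-fluorophenyl on a saturated chain carbon bound to an amine nitrogen in a ring. Among the compounds with values here, the closest precedent is a 1.8-fold lower number from compound 2 to compound 3 (0.25 log units; within the scatter), a change at the same place. The steps of an at least 5.0-fold lower number from compound 1 to compound 2 (0.69 log units; beyond the scatter) and an at least 8.8-fold lower number from compound 1 to compound 3 (0.94 log units; beyond the scatter) remove a carbonyl that neither compound 3 nor compound 4 carries, so they bear little on this change. No shift beyond the scatter is therefore expected in this assay. The estimated step is a 1.1-fold higher number from compound 3 to compound 4 (0.05 log units; within the scatter). Compound 4 is expected at 2500 nM, within an estimated range of 900 nM to 7000 nM.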

Compound 4, half-maximal inhibitory concentration: 1360 nM
Compound 4: the middle estimate sits 1.8-fold (0.26 log units) above what was measured; the measured number falls inside the stated range.
By their numbers in this assay, from the lowest: compounds 4, 3 and 2 (each within the scatter of the next, the first and the last beyond it). At a limit, above all of these: compound 1.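

The 3,5-difluorobenzyl group holds the level of the 4-fluorobenzyl group, with a 1.7-fold lower number from compound 3 to compound 4 (0.22 log units; within the scatter). Among the benzyl compounds, this position now shows its first step beyond the scatter, with a 2.9-fold lower number from compound 2 to compound 4 (0.47 log units; beyond the scatter), although compounds 2 and 3 alone showed none. Compound 1 stands at a limit of the assay, so an at least 14-fold lower number from compound 1 to compound 4 (1.16 log units; beyond the scatter) gives a bound and not a size: the limit of > 20000 nM in this assay, at which 1 of the 4 values shown sits.

The compounds shown leave open how an unsubstituted benzyl, or a longer chain between the amine nitrogen and the phenyl, would read in this assay. Also open, on these data alone, is whether a benzyl carrying a carboxylic acid would hold this level.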